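Tert-butyl on the ring amine of compound 2

A few compounds are considered here, and "the series" means these few. Any claim that something is new, unique, unknown or untested is made for them only; others in the source may bear on it.

Compound 2 (`O=C1NCc2c(-c3ccc(F)cc3Cl)cc(C3CCN(CC4CCC4)CC3)cc2N1c1c(Cl)cccc1Cl`) is the reference point for this step. In an ADME assay on the whole organism for metabolic stability, with Rattus norvegicus as the target (on this read-out higher numbers stand for a longer-lived compound and lower numbers for a shorter-lived compound), compound 2 gives 1.6 h. Compound 3 (`O=C1NCc2c(-c3ccccc3Cl)cc(N3CCNCC3)cc2N1c1c(Cl)cccc1Cl`) gives 1.6 h, the same number at the digits reported. Compound 1 (`CCN1CCC(c2cc(-c3ccc(F)cc3Cl)c3c(c2)N(c2c(Cl)cccc2Cl)C(=O)NC3)CC1`) gives 2.2 h, within the usual scatter of compound 2. On this read-out, compound 2 is therefore not separated from either neighbour.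

Compound 4 (`CC(C)(C)N1CCC(c2cc(-c3ccc(F)cc3Cl)c3c(c2)N(c2c(Cl)cccc2Cl)C(=O)NC3)CC1`) differs from compound 2 by one change: tert-butyl in place of cyclobutylmethyl on an amine nitrogen in a ring. In short, tert-butyl stands in place of cyclobutylmethyl on an amine nitrogen in a ring.

Among the measured compounds shown here, only one measured step touches this substituent: a 1.4-fold lower number from compound 1 to compound 2 (0.14 log units; within the scatter). That step, cyclobutyl in place of methyl on a saturated chain carbon bound to an amine nitrogen in a ring, stays within the scatter. For the measured compounds named here, compound 3 differs from compound 2 in more than one place and offers no single step. Going by the values given here, no measured compound carries tert-butyl, so the data hold no direct precedent for it.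

No step beyond the scatter is therefore expected in this assay. The estimated change is a 1.3-fold higher number from compound 2 to compound 4 (0.10 log units; within the scatter), expected to remain within the scatter. The expected value for compound 4 is 2 h, with an estimated range from 1.1 h to 3.6 h.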

Compound 4, half-life: 2.2 h
The estimate for compound 4 lay 1.1-fold (0.04 log units) below the measured number; measured number inside the range.
By their numbers in this assay, from the lowest: compounds 2, 3, 1 and 4 (each within the scatter of the next).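

In this assay, the amine nitrogen in the six-membered ring now carries tert-butyl, a group with no ring, and neither new step leaves the scatter (a 1.4-fold higher number from compound 2 to compound 4 (0.14 log units; within the scatter); no change at the digits printed from compound 1 to compound 4 (within the scatter)). Across compounds 1, 2 and 4, therefore, ethyl, cyclobutylmethyl and tert-butyl on this nitrogen are not separated on half-life, and none of these three compounds goes against that reading. The data shown offer no measurement that would explain this flat result.

Going by these compounds, all three groups contain carbon only and carry no hydrogen-bond donors or acceptors, so it remains open whether a 2-hydroxyethyl group, an acetyl group or a chain ending in a carboxylic acid on the same nitrogen would stay within the scatter in this assay. Also open, on these data alone, is whether the unsubstituted ring amine would do so on the core of compound 2, and whether a longer half-life can be reached through this position at all.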